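Methoxy to Methyl on the Phenylpiperazine Aryl Ring

A few compounds are considered here, and "the series" means these few. Any claim that something is new, unique, unknown or untested is made for them only; others in the source may bear on it.

Compound 1 `CCCc1nc(-c2ccccc2)c(CNCCN2CCN(c3ccccc3OC)CC2)o1`: 39.7%
Compound 2 `CCCc1nc(-c2ccccc2)c(CNCCCN2CCN(c3cccc(OC)c3)CC2)o1`: 36.4%

Of the compounds shown here, two have been measured in an assay on HEK293 cells for inhibition of Voltage-dependent T-type calcium channel subunit alpha-1G (Homo sapiens), read by fluorescence, tested at 10 uM; on this read-out lower numbers stand for less inhibition and higher numbers for more inhibition at the one concentration tested (going by the name of the read-out). Compound 1 gives 39.7% in this assay, and compound 2 gives 36.4%. These two numbers lie within the usual scatter of one another, so the data do not set compound 2 apart from compound 1; the two simply sit together in the same band of inhibition.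

The next step starts from compound 2 and leads to compound 3 `CCCc1nc(-c2ccccc2)c(CNCCCN2CCN(c3cccc(C)c3)CC2)o1`, which has not yet been measured in this assay. The change is methyl in place of methoxy on an aromatic carbon. Methyl in place of methoxy on an aromatic carbon removes one hydrogen-bond acceptor from the group that sits meta to the large group on the six-membered ring.

Going by the values given here, no measured pair shows the effect of this exchange, so there is no step in this assay to lean on. Compound 3 is expected to stay close to compound 2, with a step of a number 2.4 percentage points lower from compound 2 to compound 3 (within the scatter) that falls within the scatter. The estimate for compound 3 in this assay is 34%, ranging from 20% to 50%.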

Compound 3, a percentage reported as inhibition, at one concentration (the size of the read-out at that concentration, not a potency): 47.8%
Estimate against measurement, compound 3: 13.8 percentage points below; measured number inside the range.
By their numbers in this assay, from the lowest: compounds 2, 1 and 3 (each within the scatter of the next, the first and the last beyond it).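

In this assay, going by these compounds alone, the exchange of methoxy for methyl on an aromatic carbon meta to a large group gives the first step that can be read at this position (a number 11.4 percentage points higher from compound 2 to compound 3 (beyond the scatter)). The position therefore responds to the group it carries: going from 3-methoxyphenyl to 3-methylphenyl raises inhibition beyond the scatter, and the loss of the hydrogen-bond acceptor of methoxy does not lower it. Nothing measured on these compounds explains what lies behind this step.

What the compounds shown leave open is whether the rise is particular to methyl or would also appear with other groups at this place, such as ethyl, chlorine, trifluoromethyl or a plain hydrogen. On these data alone, it also remains open whether methyl in place of methoxy would give a similar step on compound 1, which carries its methoxy group at a different place on the aryl ring and has a different chain, so this single pair cannot yet be taken as a general rule.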